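Swapping the pyrazole on the amide nitrogen for a methoxy group

The compounds below may be only part of what the source reports. "The series", "measured", "known", "first", "only" and "open" are said of these compounds alone.

Measured compounds:
Compound 1, `Cc1ccc(OCC(=O)N(Cc2cccs2)c2cnn(C)c2)cc1`: 63000 nM
Compound 2, `Cc1ccc(OCC(=O)N(Cc2cccs2)C2COC2)cc1`: 23000 nM
Compound 3, `Cc1ccc(OCC(=O)N(Cc2cccs2)c2ccn(C)n2)cc1`: 855 nM

In an assay on HEK293 cells for agonist activity at transient receptor potential cation channel subfamily M member 8 (Homo sapiens), read by fluorescence and calcium flux, with a stated time of 15 min (on this read-out higher numbers stand for an effect only at larger amounts of compound and lower numbers for an effect already at smaller amounts), compound 3 gives the lowest number of the three; the nearest is compound 2, a 27-fold lower number from compound 2 to compound 3 (1.43 log units; beyond the scatter), and the furthest is compound 1, a 74-fold lower number from compound 1 to compound 3 (1.87 log units; beyond the scatter). Both of these steps exchange the group on the amide-type nitrogen, and both show that 1-methyl-1H-pyrazol-3-yl at that position goes with a markedly lower number than either 1-methyl-1H-pyrazol-4-yl or oxetan-3-yl.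

Compound 4, `CON(Cc1cccs1)C(=O)COc1ccc(C)cc1`, has not yet been measured. It differs from compound 3 in one place: methoxy in place of 1-methyl-1H-pyrazol-3-yl on an amide-type nitrogen. Compared with compound 3, the group on the amide-type nitrogen becomes much smaller and loses its ring. The two steps that bear on this, a 74-fold lower number from compound 1 to compound 3 (1.87 log units; beyond the scatter) and a 27-fold lower number from compound 2 to compound 3 (1.43 log units; beyond the scatter), both say that leaving the 1-methyl-1H-pyrazol-3-yl behind costs a great deal, so a large step upward in this assay is expected. The estimate for compound 4 is therefore 25000 nM, with a range from 6000 nM to 100000 nM, which means an expected step of a 29-fold higher number from compound 3 to compound 4 (1.47 log units; beyond the scatter).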

Compound 4, half-maximal effective concentration: 10 nM
Estimate against measurement, compound 4: 2500-fold (3.40 log units) above, outside the stated range (below it).
By their numbers in this assay, from the lowest: compound 4; then compound 3; then compound 2; then compound 1.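

In this assay, compound 4 overturns the reading that the 1-methyl-1H-pyrazol-3-yl group was the favoured one on the amide-type nitrogen: replacing it with methoxy, which has no ring and fewer heavy atoms, gives an 86-fold lower number from compound 3 to compound 4 (1.93 log units; beyond the scatter) rather than a loss. The same comparison holds against the other two groups, with a 2300-fold lower number from compound 2 to compound 4 (3.36 log units; beyond the scatter) for oxetan-3-yl and a 6300-fold lower number from compound 1 to compound 4 (3.80 log units; beyond the scatter) for 1-methyl-1H-pyrazol-4-yl, so among these four compounds a ring on this nitrogen is not required for a low number, and all three ring-bearing groups stand higher than methoxy. Nothing available here accounts for why methoxy goes with so low a number.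

The compounds shown cannot separate the part played by the oxygen attached to the amide-type nitrogen from that of the small size of the group, a question that a plain methyl, a hydroxy or an ethoxy group at this position would address. From the compounds shown here alone, it also remains open whether the low number of compound 4 would persist with changes elsewhere on the shared core, which stays the same in all four compounds.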